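Swapping Benzyl for Cyclohexyl in an Inactive Series

This account rests on a few compounds, and the source may have more. Where it says the series, first, only, none or still open, it means among the compounds named here.

Measured compounds:
- compound 1, `Cc1cc(C)cc(C(=O)N(CCCCCC(=O)Nc2ccccc2N)CC(=O)NC2CCCCC2)c1`: > 10000 nM (a limit of the assay)
- compound 2, `CN(C)c1ccc(C(=O)N(CCCCCC(=O)Nc2cc(F)ccc2N)CC(=O)NCc2ccccc2)cc1`: > 10000 nM (a limit of the assay)
- compound 3, `Nc1ccccc1NC(=O)CCCCCN(CC(=O)NCc1ccccc1)C(=O)c1cccc2ccccc12`: > 10000 nM (a limit of the assay)

All three compounds were tested in an assay on Sf9 cells for inhibition of protein deacetylase HDAC6 (Homo sapiens), read by fluorescence, with a stated time of 90 min; a higher number here means a weaker inhibitor, a lower number a stronger inhibitor. For compound 3 the result of > 10000 nM is only a limit, not a number. Compound 1 likewise gives a limit, > 10000 nM. Compound 2 also gives a limit, > 10000 nM. So compound 3 stands where every compound shown stands: at the limit, as the limit of > 10000 nM in this assay, at which 3 of the 3 values shown sit, describes, and no step between measured compounds has been seen.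

Compound 4, `Nc1ccccc1NC(=O)CCCCCN(CC(=O)NC1CCCCC1)C(=O)c1cccc2ccccc12`, has not yet been measured. It differs from compound 3 in one place: cyclohexyl in place of benzyl on an amide-type nitrogen. Compound 1 already carries a cyclohexyl on the corresponding amide-type nitrogen and sits at the limit with > 10000 nM, which gives no sign that this change brings a gain. No step beyond the scatter is expected in this assay; the expected step is a step that the limit leaves unreadable from compound 3 to compound 4. Compound 4 is therefore estimated at 20000 nM, ranging from 8000 nM to 100000 nM, most likely reported again as a limit.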

Compound 4, half-maximal inhibitory concentration: > 10000 nM
Compound 4 was reported as a limit (the forecaster's own chance of this, stated with the estimate: 85%); the middle value lies beyond the limit too.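

Compound 4 is again only a limit in this assay and gives > 10000 nM as its result. Going by these compounds alone, no step from compound 3 or compound 1 to compound 4 can be read, since every value is a limit: the limit of > 10000 nM in this assay, at which 4 of the 4 values shown sit.

Going by these compounds, whether any close relative gives a real number in this assay stays open, and with it how benzyl and cyclohexyl compare on this nitrogen.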